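Swapping the indole for a methoxypyrimidine on a cytotoxicity core

This account rests on a few compounds, and the source may have more. Where it says the series, first, only, none or still open, it means among the compounds named here.

In a toxicity assay on MT4 cells (Homo sapiens) for cytotoxicity, read by MTT assay, with a stated time of 5 days (on this read-out lower numbers stand for higher toxicity in this test and higher numbers for lower toxicity in this test), compound 1 `Cc1cnc(Nc2ccc(C#N)cc2)nc1Nc1c(F)cc(-c2ccco2)cc1F` gives 8100 nM and compound 2 `Cc1cc(-c2cccc3cc[nH]c23)cc(C)c1Nc1ccnc(Nc2ccc(C#N)cc2)n1` gives 1000 nM, so compound 2 stands at the lowest number of the two, the step from compound 1 lying beyond the usual scatter. Compound 3 `COc1ncc(-c2cc(C)c(Nc3ccnc(Nc4ccc(C#N)cc4)n3)c(C)c2)cn1` differs from compound 2 in one place: 2-methoxypyrimidin-5-yl in place of 1H-indol-7-yl on an aromatic carbon. Going by the values given here, no measured pair shows this kind of change, so its effect is uncertain. Compound 3 is expected to give a moderately higher number, with an estimated step of a 3.0-fold higher number from compound 2 to compound 3 (0.48 log units; beyond the scatter). In this assay compound 3 is estimated at 3000 nM, within a range of 800 nM to 12000 nM.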

Compound 3, half-maximal cytotoxic concentration: 4800 nM
For compound 3 the middle estimate is 1.6-fold (0.20 log units) below the measured one, within the range that was stated.
By their numbers in this assay, from the lowest: compound 2; then compounds 3 and 1 (each within the scatter of the next).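

At this position the group on the aromatic carbon clearly affects the read-out: in this assay, placing 2-methoxypyrimidin-5-yl where 1H-indol-7-yl stood gives a 4.8-fold higher number from compound 2 to compound 3 (0.68 log units; beyond the scatter), a modest move towards lower toxicity in this test. The swap loses the hydrogen-bond donor of the indole and brings in hydrogen-bond acceptors, but this single pair cannot separate those differences from the change of ring. Nothing available explains the shift. Still open, as far as these compounds go, is how an amine or a carboxylic acid on this same carbon would read, and whether the methoxy group itself contributes to the step.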